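From 4-pentylphenyl to cyclopropyl on a shared core

The source may report more compounds than this note shows. Statements on the series, on what has been measured and on what is new or still open speak of the compounds shown alone.

Compound 1 (`CCCCCc1ccc(-c2cn(C[C@H](O)[C@H]3OC(=O)C(OCc4ccccc4)=C3OCc3ccccc3)nn2)cc1`) is the natural starting point for this comparison. Going by the values given here, in a functional assay on A549 cells (Homo sapiens) for antiproliferative activity, read by MTT assay, with a stated time of 72 h (a higher number here means a weaker inhibitor, a lower number a stronger inhibitor), compound 1 gives 6220 nM, the only true number available so far. Compound 2 (`COc1ccc(-c2cn(C/C=C3\OC(=O)C(OCc4ccccc4)=C3OCc3ccccc3)nn2)cc1`) gives > 100000 nM, which is a limit of the assay and not a number.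

Compound 3 (`O=C1O[C@H]([C@@H](O)Cn2cc(C3CC3)nn2)C(OCc2ccccc2)=C1OCc1ccccc1`) keeps the core of compound 1 and changes one group, with cyclopropyl in place of 4-pentylphenyl on an aromatic carbon. Among the compounds with values here, no measured pair of compounds shows what a swap like this does, so any forecast is a judgment resting on a single anchor, compound 1 at 6220 nM. A large group gives way to a much smaller one, and a real loss of strength in this assay is the more likely outcome, well beyond the usual scatter. The expected change is a 6.4-fold higher number from compound 1 to compound 3 (0.81 log units; beyond the scatter), toward a weaker inhibitor. For compound 3 the estimated value is 40000 nM, with an expected range from 12000 nM to 100000 nM.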

Compound 3, half-maximal inhibitory concentration: 43900 nM
Compound 3: the middle estimate sits 1.1-fold (0.04 log units) below what was measured, within the range that was stated.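

In this assay, cyclopropyl in place of 4-pentylphenyl on an aromatic carbon of the five-membered aromatic ring with 3 nitrogen gives a 7.1-fold higher number from compound 1 to compound 3 (0.85 log units; beyond the scatter), a change toward a weaker inhibitor. Going by these compounds alone, this is the first measured step at this position, and it shows that the group there matters in this assay, even though the leaving group (11 heavy atoms) and the entering group (3 heavy atoms) both have 0 hydrogen-bond donors and 0 hydrogen-bond acceptors. Compound 2 differs from compound 1 in more than one place and stands at a limit of the assay rather than at a number, so it offers no such step: the limit of > 100000 nM in this assay, at which 1 of the 3 values shown sits.

Within the data shown here, what remains open is which part of the 4-pentylphenyl group accounts for the step, since the pentyl chain and the six-membered aromatic ring leave together in the single change from compound 1 to compound 3. A plain phenyl, a phenyl carrying an amine or a carboxylic acid, or a straight pentyl chain on the same carbon would begin to separate these parts.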